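Methoxy step on a second core in kinetic solubility

The compounds below may be only part of what the source reports. "The series", "measured", "known", "first", "only" and "open" are said of these compounds alone.

Compound 1 `CCC(=O)c1cc(-c2ccccc2)n(-c2ccc(S(N)(=O)=O)cc2)c1C` and compound 2 `CCC(=O)c1cc(-c2ccc(OC)cc2)n(-c2ccc(S(N)(=O)=O)cc2)c1C` share one core; compound 3 `CCC(=O)c1cc(-c2ccc(S(N)(=O)=O)cc2)n(-c2ccccc2)n1` is built on another, and the difference between the two cores is not broken down here. In a physicochemical assay for solubility, read by HPLC, in phosphate buffer, measured as kinetic solubility, at pH 7.4 (on this read-out lower numbers stand for lower solubility and higher numbers for higher solubility), compound 1 gives 14100 nM and compound 2 gives 12800 nM; the change methoxy in place of hydrogen on an aromatic carbon made a 1.1-fold lower number from compound 1 to compound 2 (0.04 log units; within the scatter). In this assay compound 3 gives 47200 nM, the highest of the three numbers, beyond the scatter from both compound 1 and compound 2.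

Compound 4 `CCC(=O)c1cc(-c2ccc(S(N)(=O)=O)cc2)n(-c2ccc(OC)cc2)n1` is not yet measured. It differs from compound 3 by methoxy in place of hydrogen on an aromatic carbon, the same change as between compound 1 and compound 2, at the same kind of place. For compound 4 a step of a 1.1-fold lower number from compound 3 to compound 4 (0.04 log units; within the scatter) is expected in this assay, resting on the earlier step of a 1.1-fold lower number from compound 1 to compound 2 (0.04 log units; within the scatter), which stayed within the scatter. Compound 4 is estimated at 43000 nM, with an expected range from 20000 nM to 90000 nM.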

Compound 4, solubility: 64300 nM
For compound 4 the middle estimate is 1.5-fold (0.17 log units) below the measured one, and the stated range covers the measured number.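

In this assay the methoxy change gave a 1.4-fold higher number from compound 3 to compound 4 (0.13 log units; within the scatter) and, on the core of compound 1, a 1.1-fold lower number from compound 1 to compound 2 (0.04 log units; within the scatter) as well, so on both cores the change from phenyl to 4-methoxyphenyl stayed within the scatter. This supports carrying the change across these two cores as a step too small to read, but it does not give a size or direction for the step, and two pairs say nothing about any further core. Nothing shown here accounts for the result.

The compounds shown leave open whether an amine or a carboxylic acid in place of methoxy would step beyond the scatter on either core. From the compounds shown here alone, how a longer alkoxy chain at the same place would read also stays open.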